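A few compounds are considered here, and "the series" means these few. Any claim that something is new, unique, unknown or untested is made for them only; others in the source may bear on it.

In a functional assay on HOS cells (Homo sapiens) for antiproliferative activity, with a stated time of 72 h (a higher number here means a weaker inhibitor, a lower number a stronger inhibitor), two compounds with the same core have been measured. Compound 1 `OC[C@H]1O[C@@H](n2cnc3c(NCc4cccc(F)c4)ncnc32)[C@H](O)[C@@H]1O` gives only a limit, > 166000 nM, rather than an exact number. For the measured compounds named here, compound 2 `OC[C@H]1O[C@@H](n2cnc3c(NCc4ccc(F)cc4)ncnc32)[C@H](O)[C@@H]1O` gives 13200 nM, the only exact number so far, which makes it the sole firm reference point. Compound 3 `OC[C@H]1O[C@@H](n2cnc3c(NCc4ccc(Cl)cc4)ncnc32)[C@H](O)[C@@H]1O` differs from compound 2 in a single substituent: chloro in place of fluoro on an aromatic carbon. This is chloro in place of fluoro on an aromatic carbon, para to a large group. Going by the values given here, the one measured step, with 4-fluorophenyl in place of 3-fluorophenyl, is an at least 12-fold lower number from compound 1 to compound 2 (1.09 log units; beyond the scatter). That step shows that a change on this ring can matter, but it moved the fluoro group and did not replace it, so it bears only indirectly. Among the compounds with values here, no measured step compares chloro with fluoro, so no change beyond the scatter is expected, though the uncertainty is wide. The expected step is a 1.1-fold lower number from compound 2 to compound 3 (0.04 log units; within the scatter). Compound 3 is estimated at 12000 nM, with an expected range of 4000 nM to 50000 nM.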

Compound 3, half-maximal inhibitory concentration: > 166000 nM
Compound 3 was reported as a limit; the forecaster's own chance of this, stated with the estimate: 20%; middle value at least 13-fold (1.14 log units) away from the limit.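

In this assay, chloro in place of fluoro on an aromatic carbon brings an at least 12-fold higher number from compound 2 to compound 3 (1.09 log units; beyond the scatter), and this step rests on a limit, not an exact number for compound 3. For the compounds shown here, the earlier compounds showed only that moving the fluoro group can matter; now replacing it at the same place matters as well, and among the three compounds only the 4-fluorobenzyl group gives an exact number, with the others at the assay's limit: the limit of > 166000 nM in this assay, at which 2 of the 3 values shown sit. Compound 1 and compound 3 are both limits, and the step between them cannot be read.

From the compounds shown here alone, whether any other group at this place, such as bromo, methyl or methoxy, would give an exact number remains open. So does the result for a plain benzyl group carrying no halogen at all.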